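Compound 3 to compound 4: losing the 4-phenylphenyl group

The source may hold more compounds than are shown below. What is called first, only, known or untested is meant among the compounds shown, and "the series" means these compounds.

- compound 1 `Cn1cncc1C(OCc1ccc(C#N)cc1C#CC1(O)CCCCC1)c1ccc(C#N)cc1`: 1.93 nM
- compound 2 `Cn1cncc1C(OCc1ccc(C#N)cc1C#Cc1ccc(-c2ccccc2)cc1)c1ccc(C#N)cc1`: > 0.1 nM (a limit)
- compound 3 `Cn1cncc1C(OCc1ccc(C#N)cc1-c1ccc(-c2ccccc2)cc1)c1ccc(C#N)cc1`: < 0.1 nM (a limit)

All values come from a functional assay on NIH3T3 cells (Mus musculus); on this read-out higher numbers stand for an effect only at larger amounts of compound and lower numbers for an effect already at smaller amounts. Compound 3 has no number, only the limit < 0.1 nM. Compound 2 likewise has only a limit.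

Compound 4 `Cn1cncc1C(OCc1ccc(C#N)cc1C#CCCCCO)c1ccc(C#N)cc1` carries 6-hydroxyhex-1-yn-1-yl in place of 4-phenylphenyl on an aromatic carbon. The closest guide is an at least 19-fold lower number from compound 1 to compound 3 (1.28 log units; beyond the scatter), where 4-phenylphenyl replaces 2-(1-hydroxycyclohexyl)ethynyl. The other measured step, a step that the limit leaves unreadable from compound 1 to compound 2, gives no usable size. The change to compound 4 runs the opposite way, so a large rise beyond the scatter is expected, estimated as an at least 10-fold higher number from compound 3 to compound 4 (1.00 log units; beyond the scatter). The estimate for compound 4 is 1 nM, with an expected range of 0.2 nM to 5 nM.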

Compound 4, half-maximal effective concentration: 20.9 nM
The estimate for compound 4 lay 21-fold (1.32 log units) below the measured number; measured number above the stated range.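

In this assay, among these compounds, 6-hydroxyhex-1-yn-1-yl in place of 4-phenylphenyl gives an at least 200-fold higher number from compound 3 to compound 4 (2.32 log units; beyond the scatter), so this aromatic position is far more sensitive to the group it carries than the earlier compounds could show. Among the alkynes, 4-hydroxybutyl in place of 1-hydroxycyclohexyl gives an 11-fold higher number from compound 1 to compound 4 (1.03 log units; beyond the scatter), so the two hydroxyl-bearing groups on the triple bond are not interchangeable. The step from compound 2 to compound 4 cannot be read.

The rings, triple bond and hydroxyl all change together from compound 3 to compound 4, leaving their separate contributions open. Also open, from the compounds shown here alone, is how a terminal amine or carboxylic acid in place of the hydroxyl would compare.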